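A few compounds are considered here, and "the series" means these few. Any claim that something is new, unique, unknown or untested is made for them only; others in the source may bear on it.

Measured compounds:
compound 1 `COc1ccccc1-n1cc(COc2c(/C=C\C(=O)O)ccc(OC)c2CC=C(C)C)nn1` — in a functional assay on A549 cells (Homo sapiens) for cytotoxicity, read by MTT assay, with a stated time of 24 h (a higher number here means a weaker inhibitor, a lower number a stronger inhibitor), compound 1 gives 43000 nM
compound 2 `COc1ccc(-n2cc(COc3c(/C=C\C(=O)O)ccc(OC)c3CC=C(C)C)nn2)cc1` — in this assay compound 2 gives 10200 nM
compound 3 `COc1ccc(/C=C\C(=O)O)c(OCc2cn(-c3ccc(CO)cc3)nn2)c1CC=C(C)C` — in this assay compound 3 gives "not determined" (no result reported)

Going by the values given here, the only step with numbers is a 4.2-fold lower number from compound 1 to compound 2 (0.62 log units; beyond the scatter), and it concerns just the exchange of one methoxyphenyl for another on the aromatic nitrogen. Compound 3 stands nowhere on the numbers: it carries 4-(hydroxymethyl)phenyl on that nitrogen and has no value in this assay to set beside compound 1 or compound 2.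

Compound 4 `COc1ccc(/C=C\C(=O)O)c(OCc2cn(-c3cccnc3Cl)nn2)c1CC=C(C)C` differs from compound 3 by 2-chloropyridin-3-yl in place of 4-(hydroxymethyl)phenyl on an aromatic nitrogen. Among the compounds with values here, no measured step bears on this change. The step from compound 1 to compound 2 involves neither a hydroxymethyl group nor a chloropyridinyl group, so it gives no guide to direction or size here, and with compound 3 unmeasured there is no starting point for the step itself. Within the data shown here, what can be said is that both measured compounds lie in a weak range and that the whole series so far keeps the same core, varying only the group on the aromatic nitrogen.

For compound 4 the expected value in this assay is 20000 nM, with a range of 5000 nM to 80000 nM, set wide to cover the spread between compound 1 and compound 2.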

Compound 4, half-maximal inhibitory concentration: 5600 nM
Estimate against measurement, compound 4: 3.6-fold (0.55 log units) above, and the stated range covers the measured number.
By their numbers in this assay, from the lowest: compounds 4 and 2 (each within the scatter of the next); then compound 1.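

In this assay, the aromatic nitrogen of the shared core accepts a six-membered aromatic ring with a hetero atom as well as a methoxyphenyl: 2-chloropyridin-3-yl gives a 1.8-fold lower number from compound 2 to compound 4 (0.26 log units; within the scatter), and a 7.7-fold lower number from compound 1 to compound 4 (0.89 log units; beyond the scatter). Going by these compounds alone, compound 4 therefore cannot be separated from compound 2 by this read-out, while both stand apart from compound 1, so the 2-methoxyphenyl group is no longer the only comparison for this position, and the step from compound 3 to compound 4 cannot be read since compound 3 has no value. No measurement on hand offers an explanation for these numbers.

The compounds shown leave open whether the chlorine or the ring nitrogen of 2-chloropyridin-3-yl matters for the number, a question that 2-chlorophenyl and unsubstituted pyridin-3-yl on the same nitrogen would separate. They also leave open whether an amine or a carboxylic acid on this aromatic ring would take the series out of the range held by compound 2 and compound 4.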